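Swapping the aryl group on an oxygen-ring core

This account rests on a few compounds, and the source may have more. Where it says the series, first, only, none or still open, it means among the compounds named here.

Measured compounds:
- compound 1, `NC1=NC2(CCOCC2)N(OCCCOc2cc(Cl)c(Cl)cc2Cl)C(N)=N1`: 2750 nM
- compound 2, `NC1=NC2(CCSCC2)N(OCCCOc2ccc(Cl)cc2)C(N)=N1`: 10 nM
- compound 3, `NC1=NC2(CCSCC2)N(OCCCOc2cc(Cl)c(Cl)cc2Cl)C(N)=N1`: 1 nM

In a functional assay on HCT-116 cells (Homo sapiens) for antiproliferative activity, read by MTT assay, with a stated time of 72 h (a higher number here means a weaker inhibitor, a lower number a stronger inhibitor), compound 1 gives the highest of the three numbers; compound 2 sits far lower, and compound 3 lower still. Among the compounds with values here, the one step that can be followed between measured compounds is a 10-fold lower number from compound 2 to compound 3 (1.00 log units; beyond the scatter), and it concerns the aryl group while the core is held fixed. Compound 4, `Cc1cc(C)cc(OCCCON2C(N)=NC(N)=NC23CCOCC3)c1`, has not been measured. It differs from compound 1 as follows: 3,5-dimethylphenyl in place of 2,4,5-trichlorophenyl on an oxygen on a saturated carbon. Within the data shown here, no measured pair isolates this change. The aryl step between compound 2 and compound 3 moved the number downward when more chlorine entered; the move to compound 4 removes all chlorine and so is expected to go the other way, though the size is uncertain. Compound 4 is therefore expected to give about 8000 nM in this assay, within 2000 nM to 30000 nM, corresponding to an estimated step of a 2.9-fold higher number from compound 1 to compound 4 (0.46 log units; beyond the scatter).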

Compound 4, half-maximal inhibitory concentration: 190 nM
Beside the measured number, compound 4's estimate is 42-fold (1.62 log units) above it; measured number outside the range, below it.
By their numbers in this assay, from the lowest: compound 3; then compound 2; then compound 4; then compound 1.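

On the core of compound 1, the 3,5-dimethylphenyl group in place of 2,4,5-trichlorophenyl gives a 14-fold lower number from compound 1 to compound 4 (1.16 log units; beyond the scatter) in this assay, so a chlorine-free aryl group on this oxygen-linked chain can give a lower number than the trichlorinated one. The earlier step, a 10-fold lower number from compound 2 to compound 3 (1.00 log units; beyond the scatter), ran on a different core and favoured the group with more chlorine, so the gain seen there does not carry over as a general rule for chlorine at this position. Nothing available accounts for this difference in direction.

Still open, on these data alone, is how an unsubstituted phenyl or a 4-methoxyphenyl group would behave at this place on either core. It is also unknown whether the 3,5-dimethylphenyl group would lower the number on the core of compound 3, or how a longer chain would alter the picture.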